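Cytotoxicity notes: phenyl in place of octyl

The source may hold more compounds than are shown below. What is called first, only, known or untested is meant among the compounds shown, and "the series" means these compounds.

Compound 1 `CCCCCCCCCCc1cc2cn([C@H]3C[C@H](O)[C@@H](CO)O3)c(=O)nc2o1` is the starting point in an ADME assay on HEL cells (Homo sapiens) for cytotoxicity, with a stated time of 3 days; a lower number here means that less compound is tolerated, a higher number that more compound is tolerated. There compound 1 gives > 510000 nM, which is a limit and not a number. Compound 2 `CCCCCc1cnc(-c2cc3cn([C@H]4C[C@H](O)[C@@H](CO)O4)c(=O)nc3o2)nc1` gives > 50000 nM, which is also a limit. Neither compound therefore has an exact half-maximal cytotoxic concentration, and the two readings cannot be ranked against each other.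

Compound 3 `O=c1nc2oc(CCc3ccccc3)cc2cn1[C@H]1C[C@H](O)[C@@H](CO)O1` keeps the core of compound 1 and alters only the side chain: phenyl in place of octyl on a saturated chain carbon, two bonds along the chain from an aromatic carbon. This places phenyl in place of octyl on a saturated chain carbon, two bonds along the chain from an aromatic carbon.

Going by the values given here, no measured step shows what such a change does in this assay, so the expectation rests on the two limits alone. Compound 2 gives the lower limit, > 50000 nM, and the estimate is anchored there rather than at the limit of compound 1. The expected change is an at least 5.1-fold lower number from compound 1 to compound 3 (0.70 log units; beyond the scatter), towards a lower number, although its true size is uncertain and compound 3 may again return only a limit. The estimate for compound 3 is 100000 nM, with an expected range of 25000 nM to 400000 nM.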

Compound 3, half-maximal cytotoxic concentration: > 560000 nM
Compound 3 ended at the assay's limit; the forecaster's own chance of this, stated with the estimate: 60%; at least 5.6-fold (0.74 log units) between middle value and limit.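

Compound 3 gives > 560000 nM in this assay, which is a limit and not a number. Compound 1 gives > 510000 nM, also a limit, so no step can be read from compound 1 to compound 3. The compounds shown leave open the exact half-maximal cytotoxic concentration of each compound and what phenyl in place of octyl does to it.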